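A few compounds are considered here, and "the series" means these few. Any claim that something is new, unique, unknown or untested is made for them only; others in the source may bear on it.

Measured compounds in an assay on isolated protein for displacement of a labelled ligand from metabotropic glutamate receptor 5 (Homo sapiens), with a stated time of 60 min, tested at 1 uM; on this read-out higher numbers stand for more inhibition at the one concentration tested (going by the name of the read-out) and lower numbers for less inhibition:
compound 1 `COc1ccc2ncc(S(=O)(=O)c3ccc(OC)c(Cl)c3)c(N3CCC(C)CC3)c2c1` gives 21%
compound 2 `COc1ccc2ncc(S(=O)(=O)c3ccc(C)c(F)c3)c(N3CCC(C)CC3)c2c1` gives 73%
compound 3 `COc1ccc2ncc(S(=O)(=O)c3ccc(Cl)cc3)c(N3CCC(C)CC3)c2c1` gives 91%

Compound 3 stands highest of the three in this assay; the nearest is compound 2, and the steps of a number 18 percentage points higher from compound 2 to compound 3 (beyond the scatter) and a number 70 percentage points higher from compound 1 to compound 3 (beyond the scatter) both lie beyond the scatter. Compound 4 `COc1ccc2ncc(S(=O)(=O)c3ccc(C)cc3)c(N3CCC(C)CC3)c2c1` is not yet measured. It differs from compound 3 in one place: methyl in place of chloro on an aromatic carbon. Among the compounds with values here, no measured step swaps exactly these two groups. The closest is the modest step of a number 18 percentage points higher from compound 2 to compound 3 (beyond the scatter), where a 4-chlorophenyl replaced a ring carrying a methyl together with a fluoro, so reading it for methyl alone is uncertain. Compound 4 is therefore expected to show a small decrease, a number 11 percentage points lower from compound 3 to compound 4 (beyond the scatter), perhaps within the scatter. Compound 4 is estimated at 80%, between 62% and 94%.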

Compound 4, a percentage reported as inhibition, at one concentration (the size of the read-out at that concentration, not a potency): 90%
Beside the measured number, compound 4's estimate is 10 percentage points below it; the measured number falls inside the stated range.
By their numbers in this assay, from the lowest: compound 1; then compound 2; then compounds 4 and 3 (each within the scatter of the next).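

On the sulfonyl sulfur, 4-methylphenyl and 4-chlorophenyl read alike in this assay, with a number 1 percentage points lower from compound 3 to compound 4 (within the scatter), so methyl serves as well as chloro at this place on the ring. Hydrogen in place of fluoro gives a number 17 percentage points higher from compound 2 to compound 4 (beyond the scatter), which separates the fluoro from the methyl, and 4-methylphenyl in place of 3-chloro-4-methoxyphenyl gives a number 69 percentage points higher from compound 1 to compound 4 (beyond the scatter). No measured evidence accounts for these steps. As far as these compounds go, whether a nitrile or a trifluoromethyl at this place would read like methyl and chloro remains open.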